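The compounds below may be only part of what the source reports. "The series", "measured", "known", "first", "only" and "open" are said of these compounds alone.

Compound 1 `Cc1ccc(/N=C2\C(=O)Nc3ccc(S(=O)(=O)N4CCOCC4)cc32)cc1`: 309000 nM
Compound 2 `Cc1ccc(S(=O)(=O)N/N=C2\C(=O)Nc3ccc(S(=O)(=O)N4CCOCC4)cc32)cc1`: 261000 nM

Going by the values given here, only two compounds sharing one core have been measured so far. In an ADME assay on WI-38 cells (Homo sapiens) for cytotoxicity, read by sulforhodamine B assay, with a stated time of 24 h (a higher number here means a weaker inhibitor, a lower number a stronger inhibitor), compound 1 gives 309000 nM and compound 2 gives 261000 nM. These two numbers lie within the usual scatter of each other, so they cannot be put in order, and compound 1 stands level with compound 2.

The next compound to be measured is compound 3 `CC(=O)c1cccc(/N=C2\C(=O)Nc3ccc(S(=O)(=O)N4CCOCC4)cc32)c1`. It keeps the core of compound 1 but carries 3-acetylphenyl in place of 4-methylphenyl on a double-bonded nitrogen.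

Among the compounds with values here, no measured step from a change in one place is available to guide an expectation for this swap. What remains is the level set by compound 1 at 309000 nM and compound 2 at 261000 nM. A step beyond the scatter in this assay is therefore not expected, in either direction. The expected step is small, a 1.4-fold lower number from compound 1 to compound 3 (0.15 log units; within the scatter). For compound 3 the estimated value is 220000 nM, with an expected range from 100000 nM to 420000 nM.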

Compound 3, half-maximal inhibitory concentration: 177000 nM
Beside the measured number, compound 3's estimate is 1.2-fold (0.09 log units) above it, within the range that was stated.
By their numbers in this assay, from the lowest: compounds 3, 2 and 1 (each within the scatter of the next).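

In this assay, the replacement of 4-methylphenyl by 3-acetylphenyl on a double-bonded nitrogen gives the first step measured at this position, a 1.7-fold lower number from compound 1 to compound 3 (0.24 log units; within the scatter), and this step stays within the usual scatter. Going by these compounds alone, the position therefore takes an aryl group with more heavy atoms and a hydrogen-bond acceptor, which 4-methylphenyl lacks, without a change that this assay can distinguish from repeat variation, although this single pair shows only that one swap. No measurement is available that would explain this result.

The swap removes the methyl and brings in the acetyl at a different place on the ring in a single step, so the compounds shown cannot separate the effect of the group from the effect of where it sits. As far as these compounds go, it also remains open whether a different kind of group on this aromatic ring, such as an amine or a carboxylic acid, would shift the number beyond the scatter, or whether the level seen so far would hold.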